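A Methoxy Takes the Place of an Acetamido

The source may hold more compounds than are shown below. What is called first, only, known or untested is meant among the compounds shown, and "the series" means these compounds.

Compound 1, `COc1ccc(C(=O)CSC(=S)SCCNC(C)=O)cc1`, gives 1640 nM in an assay on HEK293 cells for inhibition of protein deacetylase HDAC6 (Homo sapiens); a higher number here means a weaker inhibitor, a lower number a stronger inhibitor.
Compound 2, `CCSC(=S)SCC(=O)c1ccc(NS(C)(=O)=O)cc1`, gives 1090 nM in this assay.

Compound 1 holds the higher of the two numbers shown, yet its gap to compound 2 lies within the usual scatter. Compound 3, `COCCSC(=S)SCC(=O)c1ccc(OC)cc1`, is not yet measured. It differs from compound 1 in one place: methoxy in place of acetamido on a saturated chain carbon, two bonds along the chain from a sulfur. Within the data shown here, no measured pair shows this change, so its size is unknown here. Compound 2 carries no acetamido and still gives 1090 nM, which makes a result near compound 1 seem likely for compound 3. The step of a 1.1-fold lower number from compound 1 to compound 3 (0.04 log units; within the scatter) is expected to stay within the scatter. Compound 3 is estimated at 1500 nM, ranging from 600 nM to 4000 nM.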

Compound 3, half-maximal inhibitory concentration: 2130 nM
Estimate against measurement, compound 3: 1.4-fold (0.15 log units) below, and the stated range covers the measured number.
By their numbers in this assay, from the lowest: compounds 2, 1 and 3 (each within the scatter of the next).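

In this assay, methoxy in place of acetamido on a saturated chain carbon, two bonds along the chain from a sulfur, gives a 1.3-fold higher number from compound 1 to compound 3 (0.11 log units; within the scatter). Among these compounds, this is the first measured step at this position, and it shows that the acetamido group, with its hydrogen-bond donor, can leave without a change beyond the scatter. No evidence at hand bears on why the step has this size.

On these data alone, whether an amine, a carboxylic acid or a longer chain at this position would move the number beyond the scatter stays open.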